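A methoxy group added to compound 1

The compounds below may be only part of what the source reports. "The series", "measured", "known", "first", "only" and "open" are said of these compounds alone.

In a functional assay on Bel-7402 cells (Homo sapiens) for inhibition, read by MTT assay, with a stated time of 24 h, tested at 10 ug/mL (a higher number here means more inhibition of growth at the concentration tested, a lower number less inhibition of growth), compound 1 (`O=C(CCCCC(S)CCS)Nc1ccccc1`) stands at 3.72% and compound 2 (`O=C(CCCCC(S)CCS)Nc1cccc(C(F)(F)F)c1`) at 1.21% within the scatter of each other. Compound 3 (`COc1ccc(NC(=O)CCCCC(S)CCS)cc1`) differs from compound 1 by methoxy in place of hydrogen on an aromatic carbon in one place, methoxy in place of hydrogen on an aromatic carbon. Within the data shown here, the only measured step that bears on this is trifluoromethyl in place of hydrogen on an aromatic carbon, which gives a number 2.5 percentage points lower from compound 1 to compound 2 (within the scatter) and so no step beyond the scatter is expected in either direction. The expected outcome is a number 0.3 percentage points higher from compound 1 to compound 3 (within the scatter) within the scatter. Compound 3 is estimated at 4% (expected range -3% to 13%).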

Compound 3, percent growth inhibition at one concentration: 10.4%
For compound 3 the middle estimate is 6.4 percentage points below the measured one; the range from low to high includes it.
By their numbers in this assay, from the lowest: compounds 2, 1 and 3 (each within the scatter of the next).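

In this assay, methoxy in place of hydrogen on an aromatic carbon, para to a large group, gives a small step (a number 6.7 percentage points higher from compound 1 to compound 3 (within the scatter)). This position therefore accepts an oxygen-linked group of 2 heavy atoms without a step beyond the scatter, so the change does not separate the two compounds. Nothing measured here offers an account of this result.

Going by these compounds, whether an amine or a carboxylic acid at this same position would give a step beyond the scatter stays open. So does the outcome for a longer chain on the oxygen, such as ethoxy.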